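This account rests on a few compounds, and the source may have more. Where it says the series, first, only, none or still open, it means among the compounds named here.

In a functional assay on U-937 cells (Homo sapiens) for antiproliferative activity, read by MTT assay, with a stated time of 24 h; a higher number here means a weaker inhibitor, a lower number a stronger inhibitor:
- compound 1 `CCCCc1oc2ccccc2c1C(=O)c1ccc(OCC(=O)N2CCCCC2)cc1`: 37100 nM
- compound 2 `CCCCc1oc2ccccc2c1C(=O)c1ccc(OCC(=O)N[C@@H](C)c2ccccc2)cc1`: 33800 nM
- compound 3 `CCCCc1oc2ccccc2c1C(=O)c1ccc(OCCCC(=O)N2CCCC2)cc1`: 7500 nM

Compound 3 holds the lowest number of the three, beyond the scatter from both others. Compound 4 `CCCCc1oc2ccccc2c1C(=O)c1ccc(OCCCC(=O)N2CCCCC2)cc1` carries piperidin-1-yl in place of pyrrolidin-1-yl on a carbonyl carbon.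

Going by the values given here, no measured step isolates this swap. The closest guide, also on a carbonyl carbon, is a 1.1-fold lower number from compound 1 to compound 2 (0.04 log units; within the scatter). The larger 4.9-fold lower number from compound 1 to compound 3 (0.69 log units; beyond the scatter) and a 4.5-fold lower number from compound 2 to compound 3 (0.65 log units; beyond the scatter) also change the chain, so they cannot be assigned to the ring alone. In this assay, no step beyond the scatter is therefore expected, although compound 1, which also bears piperidin-1-yl, leaves some room upward at 37100 nM.

The expected change is a 1.3-fold higher number from compound 3 to compound 4 (0.10 log units; within the scatter). For compound 4 the estimated value is 9500 nM, with an expected range of 4500 nM to 25000 nM.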

Compound 4, half-maximal inhibitory concentration: 16600 nM
The estimate for compound 4 lay 1.7-fold (0.24 log units) below the measured number; the range from low to high includes it.
By their numbers in this assay, from the lowest: compound 3; then compound 4; then compounds 2 and 1 (each within the scatter of the next).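

In this assay, going by these compounds alone, a 2.2-fold higher number from compound 3 to compound 4 (0.35 log units; beyond the scatter) gives the first isolated reading of piperidin-1-yl in place of pyrrolidin-1-yl on a carbonyl carbon, and it lies beyond the scatter. With piperidin-1-yl kept, the chain change alone still gives a 2.2-fold lower number from compound 1 to compound 4 (0.35 log units; beyond the scatter), and a 2.0-fold lower number from compound 2 to compound 4 (0.31 log units; beyond the scatter) runs the same way. No evidence here accounts for either step.

Going by these compounds, it remains open whether pyrrolidin-1-yl would give a similar step on the shorter chain of compound 1. Also open, on these data alone, is how morpholin-4-yl on the carbonyl carbon, or a still longer chain, would compare.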